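Bromo for methyl on two closely related nitroimidazole cores

The source may report more compounds than this note shows. Statements on the series, on what has been measured and on what is new or still open speak of the compounds shown alone.

Compound 1 `Cc1ccc(/C=C/c2ncc([N+](=O)[O-])n2C)cc1` and compound 3 `Cc1ccc(CCc2ncc([N+](=O)[O-])n2C)cc1` share most of their structure; the difference between the two cores is not broken down here. In an ADME assay on HeLa cells (Homo sapiens) for cytotoxicity, read by resazurin assay, with a stated time of 2 days (on this read-out lower numbers stand for stronger inhibition and higher numbers for weaker inhibition), compound 1 gives only a limit of the assay, > 100000 nM. Compound 2 `Cn1c([N+](=O)[O-])cnc1/C=C/c1ccc(Br)cc1` carries bromo in place of methyl on an aromatic carbon and in this assay gives 72400 nM, so that an at least 1.3-fold lower number from compound 1 to compound 2 (0.14 log units; that floor lies within the scatter). Compound 3 in this assay likewise gives only a limit, > 100000 nM; this is the limit of > 100000 nM in this assay, at which 2 of the 3 values shown sit. Compound 4 `Cn1c([N+](=O)[O-])cnc1CCc1ccc(Br)cc1` differs from compound 3 by bromo in place of methyl on an aromatic carbon, the same change as that from compound 1 to compound 2. The expected step is an at least 1.2-fold lower number from compound 3 to compound 4 (0.09 log units; that floor lies within the scatter), resting on an at least 1.3-fold lower number from compound 1 to compound 2 (0.14 log units; that floor lies within the scatter). Compound 4 is therefore expected to give about 80000 nM, between 40000 nM and 150000 nM, with a real chance of only a limit.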

Compound 4, half-maximal inhibitory concentration: 97700 nM
Compound 4: the middle estimate sits 1.2-fold (0.09 log units) below what was measured, within the range that was stated.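

In this assay, bromo in place of methyl on an aromatic carbon gives an at least 1.0-fold lower number from compound 3 to compound 4 (0.01 log units; that floor lies within the scatter). Set beside the earlier step, this shows no disagreement between the two cores, but it does not establish agreement either: the same change on two cores in this assay, an at least 1.3-fold lower number (0.14 log units; that floor lies within the scatter) from compound 1 to compound 2 and an at least 1.0-fold lower number (0.01 log units; that floor lies within the scatter) from compound 3 to compound 4; the limit leaves it open whether they differ Both steps start from a compound that gives only a limit, so the true size of the change on either core cannot be stated, nor can it be said that the change carries over unaltered: the limit of > 100000 nM in this assay, at which 2 of the 4 values shown sit.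

The compounds shown leave open whether another group at this place, such as an amine or a carboxylic acid, would give a value clearly away from that limit in this assay. They also leave open whether a longer chain would do so.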